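Chain extension on the octyl amide of compound 1

This account rests on a few compounds, and the source may have more. Where it says the series, first, only, none or still open, it means among the compounds named here.

Compound 1 `CCCCCCCCNC(=O)[C@@H](NC(=O)c1ccccc1)[C@@H](C)O` stands second highest of the three numbers in a functional assay on HepG2 cells (Homo sapiens) for cytotoxicity, read by MTT assay, with a stated time of 48 h (a higher number here means a weaker inhibitor, a lower number a stronger inhibitor), where compound 1 gives 136000 nM. Its nearest neighbour is compound 2 `CCCCCCCCNC(=O)[C@@H](NC(=O)c1cccs1)[C@@H](C)O`, which in this assay gives 149000 nM; the step of a 1.1-fold higher number from compound 1 to compound 2 (0.04 log units; within the scatter) lies within the scatter. Compound 3 `CCCCCCCCNC(=O)[C@@H](NC(=O)/C=C/c1ccccc1)[C@@H](C)O` is the furthest, giving 55600 nM in this assay; the steps of a 2.4-fold lower number from compound 1 to compound 3 (0.39 log units; beyond the scatter) and a 2.7-fold lower number from compound 2 to compound 3 (0.43 log units; beyond the scatter) are modest but beyond the scatter.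

Compound 4 `CCCCCCCCCCCCCCNC(=O)[C@@H](NC(=O)c1ccccc1)[C@@H](C)O` differs from compound 1 by hexyl in place of hydrogen on a saturated chain carbon, eight bonds along the chain from an amide-type nitrogen; the phenyl on the carbonyl carbon of compound 1 is kept. Within the data shown here, none of the measured steps touches the chain: each of the three exchanges the group on the carbonyl carbon and leaves the octyl chain as it is. Among the measured compounds shown here, the only guide is the narrowness of the measured range, running from compound 2 to compound 3, within which every measured variant falls. For the measured compounds named here, for compound 4 no step beyond the scatter can be expected with confidence in this assay, so the expected step is a 1.4-fold lower number from compound 1 to compound 4 (0.13 log units; within the scatter), with a wide band because no step or value bears on the chain. Compound 4 is estimated at 100000 nM, with a range from 25000 nM to 400000 nM.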

Compound 4, half-maximal inhibitory concentration: 54200 nM
For compound 4 the middle estimate is 1.8-fold (0.27 log units) above the measured one; the measured number falls inside the stated range.
By their numbers in this assay, from the lowest: compounds 4 and 3 (each within the scatter of the next); then compounds 1 and 2 (each within the scatter of the next).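

In this assay, among these compounds, the added hexyl gives a 2.5-fold lower number from compound 1 to compound 4 (0.40 log units; beyond the scatter), the first step read on the saturated chain rather than on the carbonyl carbon. Among the compounds shown here, with the phenyl on the carbonyl carbon kept, this modest step shows that the number responds to a change on the chain, so exchanges on the carbonyl carbon are not the only changes that register beyond the scatter. No measurement at hand bears on the reason for this step.

A single extension gives no trend with chain length, so the compounds shown do not tell whether a shorter chain such as butyl, a longer chain than that of compound 4, or a chain ending in an amine or a carboxylic acid would continue, flatten or reverse this step. Also open, on these data alone, is whether the same hexyl extension on compound 3, which carries 2-phenylethenyl on the carbonyl carbon, would give a step of similar size to the one seen with phenyl.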